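Adding a larger group to the ring of compound 2

This account rests on a few compounds, and the source may have more. Where it says the series, first, only, none or still open, it means among the compounds named here.

Values in a functional assay on the whole organism (strain Sprague-Dawley) for inhibition, with Rattus norvegicus as the target, with a stated time of 10 min; on this read-out higher numbers stand for an effect only at larger amounts of compound and lower numbers for an effect already at smaller amounts:
Compound 1 `O=C(O)c1cnc(-c2ccccc2O)[nH]c1=O`: > 5 mg/kg, a limit and not a number
Compound 2 `CCOc1ccccc1-c1ncc(C(=O)O)c(=O)[nH]1`: 0.5 mg/kg
Compound 3 `CCCCOc1ccccc1-c1ncc(C(=O)O)c(=O)[nH]1`: 0.5 mg/kg

Compound 2 stands level with compound 3. The longer chain gives no change at the digits printed from compound 2 to compound 3 (within the scatter). Compound 4 `CCOC(=O)C(=O)Nc1ccc(OCC)c(-c2ncc(C(=O)O)c(=O)[nH]2)c1` differs from compound 2 in one place: ((ethoxycarbonyl)carbonyl)amino in place of hydrogen on an aromatic carbon, para to an ethoxy group. The measured steps concern only the group on the oxygen: an at least 10-fold lower number from compound 1 to compound 2 (1.00 log units; beyond the scatter) and an at least 10-fold lower number from compound 1 to compound 3 (1.00 log units; beyond the scatter). Compound 4 keeps the ethoxy group, and a value near compound 2 at 0.5 mg/kg is therefore expected. Within the data shown here, no measured step tests the new place, and the range stays wide. The expected step is a 1.7-fold lower number from compound 2 to compound 4 (0.22 log units; within the scatter), with nothing expected beyond the scatter. For compound 4 the estimated value in this assay is 0.3 mg/kg, from 0.05 mg/kg to 2 mg/kg.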

Compound 4, dose for 50% inhibition: 25 mg/kg
For compound 4 the middle estimate is 83-fold (1.92 log units) below the measured one; measured number above the stated range.
By their numbers in this assay, from the lowest: compounds 2 and 3 (each within the scatter of the next); then compound 4.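

In this assay, among these compounds, the earlier compounds varied only the group on the oxygen, and compound 4 is the first to change the aromatic carbon para to the ethoxy group. This place is far from indifferent: ((ethoxycarbonyl)carbonyl)amino in place of hydrogen gives a 50-fold higher number from compound 2 to compound 4 (1.70 log units; beyond the scatter), even with the ethoxy group kept. Nothing shown gives a cause for this loss.

From the compounds shown here alone, whether the loss belongs to the position or to this particular group stays open. A plain amine or a carboxylic acid on the same carbon would separate the two.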